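A Smaller Aryl Group on the Amide of Compound 1

The source may report more compounds than this note shows. Statements on the series, on what has been measured and on what is new or still open speak of the compounds shown alone.

Compound 1 `O=C(c1cc2ccccc2o1)N1CCC(NCCSC(c2ccc(F)cc2)c2ccc(F)cc2)CC1` gives the lowest number of the three compounds measured in an assay on membranes from Cortex for displacement of a labelled ligand from Sigma non-opioid intracellular receptor 1 (Cavia porcellus), read by scintillation counting, with a stated time of 120 min (a higher number here means a weaker inhibitor, a lower number a stronger inhibitor), where compound 1 reads 304 nM. Compound 3 `CC(C)(C)CN1CCC(NCC[S+]([O-])C(c2ccc(F)cc2)c2ccc(F)cc2)CC1` stands nearest, and in this assay compound 3 gives 542 nM, a gap within the scatter, so no order between the two can be claimed. Compound 2 `CC(C)(C)C(=O)N1CCC(NCC[S+]([O-])C(c2ccc(F)cc2)c2ccc(F)cc2)CC1` lies furthest away, and in this assay compound 2 gives 11200 nM. Going by the values given here, the one step among the measured compounds, a 21-fold lower number from compound 2 to compound 3 (1.32 log units; beyond the scatter), concerns the nitrogen of the ring and not the carbonyl, so it does not bear on the change considered here. Compound 2 and compound 3 each differ from compound 1 in more than one place, so only their bare values stand beside it.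

Compound 4 `O=C(c1ccccc1F)N1CCC(NCCSC(c2ccc(F)cc2)c2ccc(F)cc2)CC1` differs from compound 1 by 2-fluorophenyl in place of 1-benzofuran-2-yl on a carbonyl carbon. Among the compounds with values here, no measured step tests this change, and the expectation rests on the values of compound 1 and compound 2 alone. For compound 4 a modest rise in number is expected, a 2.0-fold higher number from compound 1 to compound 4 (0.30 log units; within the scatter), close to the scatter. Compound 4 is therefore estimated at 600 nM in this assay, within a range from 150 nM to 2500 nM.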

Compound 4, inhibition constant: 3.57 nM
Compound 4: middle estimate off by 170-fold (2.23 log units), on the high side; the measured number lies below the stated range.
By their numbers in this assay, from the lowest: compound 4; then compounds 1 and 3 (each within the scatter of the next); then compound 2.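

In this assay, going by these compounds alone, an 85-fold lower number from compound 1 to compound 4 (1.93 log units; beyond the scatter) shows that the group on this carbonyl carbon strongly affects the number, a point the earlier compounds could not address because their only step, a 21-fold lower number from compound 2 to compound 3 (1.32 log units; beyond the scatter), concerned the group on the ring nitrogen. The change removes 1-benzofuran-2-yl, with its five-membered aromatic ring, its six-membered aromatic ring and its one hydrogen-bond acceptor, and brings in 2-fluorophenyl, with a single six-membered aromatic ring, no hydrogen-bond acceptor and fewer heavy atoms, but this single step cannot show which of these differences matters. No measurement shown here accounts for the size of the step.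

From the compounds shown here alone, whether the fluorine itself is needed remains open, as does the effect of a plain phenyl or a pyridine ring on this carbonyl carbon. Going by these compounds, it is also open whether 2-fluorophenyl would give a step of similar size in a compound carrying the sulfoxide found in compound 2 and compound 3.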